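Chloro-to-hydrogen step on the pyridyl ring of the oxime series

The source may report more compounds than this note shows. Statements on the series, on what has been measured and on what is new or still open speak of the compounds shown alone.

Measured so far:
compound 1 `Fc1ccc(CCCCN2CCN(c3ccc(Cl)cc3)CC2)cc1`, an assay on cells with Sigma non-opioid intracellular receptor 1 (Homo sapiens) as the target (on this read-out lower numbers stand for stronger inhibition and higher numbers for weaker inhibition), 36 nM
compound 2 `O/N=C(/CCCN1CCCN(c2ccc(Cl)cn2)CC1)c1ccc(F)cc1`, this assay 113 nM

Of the two numbers in hand, compound 2 has the higher one, and its gap to compound 1 lies beyond the usual scatter. Compound 3 `O/N=C(/CCCN1CCCN(c2ccccn2)CC1)c1ccc(F)cc1` is not yet measured. Relative to compound 2 it shows hydrogen in place of chloro on an aromatic carbon, two atoms from the ring nitrogen, para to a large group; one bond further out this reads as 5-chloropyridin-2-yl becoming pyridin-2-yl. Within the data shown here, no pair of measured compounds separated by a single change is available, so nothing in hand calibrates this step. Removing a single heavy atom from the periphery is expected to shift the number only modestly, most likely upward, so a 2.2-fold higher number from compound 2 to compound 3 (0.34 log units; beyond the scatter) is the step estimated, possibly no larger than the scatter. Compound 3 is therefore estimated at 250 nM, within 80 nM to 800 nM.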

Compound 3, inhibition constant: 70 nM
Estimate against measurement, compound 3: 3.6-fold (0.55 log units) above; measured number below the stated range.
By their numbers in this assay, from the lowest: compounds 1, 3 and 2 (each within the scatter of the next, the first and the last beyond it).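

In this assay, among these compounds, the only single-change pair in the oxime series gives a 1.6-fold lower number from compound 2 to compound 3 (0.21 log units; within the scatter) for hydrogen in place of chloro, so 5-chloropyridin-2-yl and pyridin-2-yl are not separated on this read-out. At this aromatic carbon, two atoms from the ring nitrogen and para to a large group, the chlorine is therefore not required for a number in this range, at least in this one pair. No accompanying data address why the two compounds are not separated.

From the compounds shown here alone, it remains open whether a larger group on the same carbon, such as trifluoromethyl or methoxy, would give a step beyond the scatter. Going by these compounds, it is also open how much the oxime itself matters, which a ketone in its place would test.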